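Notes on a hydroxy step from compound 1

This account rests on a few compounds, and the source may have more. Where it says the series, first, only, none or still open, it means among the compounds named here.

Values in a functional assay on UACC-62 cells (Homo sapiens) for inhibition, read by sulforhodamine B assay, with a stated time of 48 h; on this read-out lower numbers stand for stronger inhibition of growth and higher numbers for weaker inhibition of growth:
- compound 1 `CC1(/C=C/c2ccccc2)C=CC(=O)O1`: 97200 nM
- compound 2 `CC1(/C=C/c2ccccc2C(F)(F)F)C=CC(=O)O1`: 17700 nM
- compound 3 `CC1(/C=C/c2ccccc2O)C=CC(=O)O1`: 92500 nM

Compound 1 stands with compound 3 at the high end of these numbers, the side of weaker growth inhibition, and compound 2 lies clear of both. The unmeasured compound 4 `CC1(/C=C/c2cccc(O)c2)C=CC(=O)O1` differs from compound 1 by one change: hydroxy in place of hydrogen on an aromatic carbon. Among the measured compounds shown here, the nearest precedent is the same exchange of hydrogen for hydroxy at another aromatic carbon, a 1.1-fold lower number from compound 1 to compound 3 (0.02 log units; within the scatter). The trifluoromethyl exchange, a 5.5-fold lower number from compound 1 to compound 2 (0.74 log units; beyond the scatter), brings in a different group and bears less directly, as does a 5.2-fold higher number from compound 2 to compound 3 (0.72 log units; beyond the scatter). For the measured compounds named here, with only one hydroxy example, the effect of placing the hydroxy elsewhere remains unmeasured, so the range stays wide. In this assay, no step beyond the scatter is expected, and the estimated step is a 1.1-fold lower number from compound 1 to compound 4 (0.06 log units; within the scatter). Compound 4 is estimated at 85000 nM, with an expected range of 40000 nM to 150000 nM.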

Compound 4, concentration for total growth inhibition: 108000 nM
Beside the measured number, compound 4's estimate is 1.3-fold (0.10 log units) below it; the range from low to high includes it.
By their numbers in this assay, from the lowest: compound 2; then compounds 3, 1 and 4 (each within the scatter of the next).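

In this assay, hydroxy in place of hydrogen on an aromatic carbon, here meta to a group of 9 heavy atoms, gives a 1.1-fold higher number from compound 1 to compound 4 (0.05 log units; within the scatter). Together with compound 3, this gives a second aromatic carbon at which the hydroxy exchange leaves the number within the scatter of compound 1, so among the compounds shown only compound 2, with trifluoromethyl, stands apart. Nothing on hand explains why this hydroxy exchange makes so little difference.

As far as these compounds go, it remains open whether trifluoromethyl at the position of the hydroxy in compound 4 would match a 5.5-fold lower number from compound 1 to compound 2 (0.74 log units; beyond the scatter), or whether that step belongs to the aromatic carbon carrying it in compound 2. Also open, from the compounds shown here alone, is how an amine, a carboxylic acid or a methoxy group would behave at this position.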